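Compound 1 Trades (4-Ethylphenyl)amino for Azetidin-1-yl

The compounds below may be only part of what the source reports. "The series", "measured", "known", "first", "only" and "open" are said of these compounds alone.

In a functional assay on HeLa cells (Homo sapiens) for inhibition, read by sulforhodamine B assay (a higher number here means a weaker inhibitor, a lower number a stronger inhibitor), compound 1 (`CCc1ccc(NC2=CC(=O)c3c(nc4n3[C@H]3OC[C@@H](O)[C@H]3OC4)C2=O)cc1`) gives 6510 nM. Two relatives share its core: compound 2 (`O=C1C(Nc2ccc(C(F)(F)F)cc2)=CC(=O)c2c1nc1n2[C@H]2OC[C@@H](O)[C@H]2OC1`) gives 8920 nM, and compound 3 (`O=C1C=C(Nc2ccc(Br)cc2)C(=O)c2c1nc1n2[C@H]2OC[C@@H](O)[C@H]2OC1`) gives 3830 nM. Compound 1 holds the second highest of these three numbers, and its distance to each of the other two lies within the scatter of repeated measurements.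

The next compound to be measured is compound 4 (`O=C1C(N2CCC2)=CC(=O)c2c1nc1n2[C@H]2OC[C@@H](O)[C@H]2OC1`), in which azetidin-1-yl stands in place of (4-ethylphenyl)amino on a double-bonded ring carbon: azetidin-1-yl in place of (4-ethylphenyl)amino on a double-bonded ring carbon. Among the compounds with values here, only one measured step bears on this change, and only loosely. Trifluoromethyl in place of ethyl on an aromatic carbon gives a 1.4-fold higher number from compound 1 to compound 2 (0.14 log units; within the scatter), which is within the scatter. That step alters only a group on the aromatic ring, whereas compound 4 loses the ring and the whole group carrying it. The measured compounds contain no replacement of this kind, so they point in no direction in this assay. The expected step is a 1.1-fold lower number from compound 1 to compound 4 (0.04 log units; within the scatter), which is nothing beyond the scatter, and this expectation is held loosely. For compound 4 the estimated value is 6000 nM, with an expected range from 1800 nM to 20000 nM.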

Compound 4, half-maximal inhibitory concentration: > 16000 nM
Compound 4: a limit, no number; the forecaster's own chance of this, stated with the estimate: 10%; middle value at least 2.6-fold (0.42 log units) from the limit.
By their numbers in this assay, from the lowest: compounds 3, 1 and 2 (each within the scatter of the next, the first and the last beyond it). At a limit, above all of these: compound 4.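

Exchanging the whole (4-ethylphenyl)amino group for azetidin-1-yl on this double-bonded ring carbon gives an at least 2.4-fold higher number from compound 1 to compound 4 (0.39 log units; beyond the scatter), whereas altering only a group on the aromatic ring gave a 1.4-fold higher number from compound 1 to compound 2 (0.14 log units; within the scatter). In this assay compound 4 gives > 16000 nM, which is a limit of the assay and not a number, so the full size of this step stays unknown: the limit of > 16000 nM in this assay, at which 1 of the 4 values shown sits. Among the four compounds shown, then, what stands on this carbon matters, and a change of the entire group reaches further than the change made at the far end of the aromatic ring in compound 2.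

The step from compound 1 to compound 4 removes the aromatic ring and the hydrogen-bond donor and also shortens the group, and these compounds cannot separate those changes from one another. A cyclohexylamino group would remove the aromatic ring while keeping an amino hydrogen, and a piperidin-1-yl ring would test a larger ring without one, so either could help show which part of the exchange carries the loss.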